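A few compounds are considered here, and "the series" means these few. Any claim that something is new, unique, unknown or untested is made for them only; others in the source may bear on it.

In an ADME assay for metabolic stability, read by HPLC, in simulated intestinal fluid, with a stated time of 12 h, at pH 6.8 (a lower number here means that the compound disappears faster, a higher number that the compound lasts longer), compound 1 `O=C(O)[C@H](CO)NC(=O)[C@@H]1C[C@@H](O)CN1` reaches > 12 h, which is a limit of the assay rather than a number. Compound 2 `O=C(O)[C@H](CO)NC(=O)[C@@H]1C[C@H](O)CN1` likewise reaches > 12 h, again a limit. The step that the two limits leave unreadable from compound 1 to compound 2 therefore cannot be read, since both values sit at the limit of > 12 h in this assay, at which 2 of the 2 values shown sit, while (the fact that compounds 1 and 2 differ only in the configuration as drawn). Compound 3 `O=C(O)[C@@H](CO)NC(=O)[C@H]1C[C@H](O)CN1` differs from compound 2 in that (the two compounds have the same atoms and bonds and differ only in configuration as drawn: 2 of 3 stereo elements differ; a stereocentre at a saturated chain carbon is drawn S in compound 2 and R in compound 3; a stereocentre at a saturated ring carbon is drawn S in compound 2 and R in compound 3). Among the compounds with values here, because the limit of > 12 h in this assay, at which 2 of the 2 values shown sit, holds for both compounds measured so far, a change of configuration alone gives no reason to expect compound 3 to fall short of that limit. For compound 3 the expected half-life is 20 h, within 10 h to 40 h, which means an expected step that the limit leaves unreadable from compound 2 to compound 3.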

Compound 3, half-life in the ADME assay: > 12 h
Compound 3: only a limit was reported; the forecaster's own chance of this, stated with the estimate: 85%; the middle value lies beyond the limit too.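

Within the data shown here, no step among compound 1, compound 2 and compound 3 can be read: every value shown is a limit of its assay. In a physicochemical assay for metabolic stability, read by HPLC, with a stated time of 12 h, at pH 1.2 (a higher number here means that the compound lasts longer, a lower number that the compound disappears faster), compound 2 gives > 12 h, which is a limit. In the physicochemical assay compound 3 gives > 12 h, again a limit. The compounds shown leave open whether configuration changes the half-life in either assay.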